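Methyl for isopropyl on the aromatic nitrogen: cytotoxicity notes

A few compounds are considered here, and "the series" means these few. Any claim that something is new, unique, unknown or untested is made for them only; others in the source may bear on it.

Of the compounds shown here, three have so far been measured in a functional assay on MCF7 cells (Homo sapiens) for cytotoxicity, read by MTT assay, with a stated time of 48 h; a lower number here means a stronger inhibitor, a higher number a weaker inhibitor. Compound 1 `CC(C)n1c(/C=C2/C(=O)Nc3ccc(F)cc32)nc2ccccc21` gives 29000 nM. Compound 2 `Cn1c(/C=C2/C(=O)Nc3ccc(F)cc32)nc2ccccc21` gives 31600 nM in this assay. Compound 3 `CC(C)n1c(/C=C2/C(=O)Nc3ccc(Cl)cc32)nc2ccccc21` gives 24000 nM in this assay.

Two single changes connect these. methyl in place of isopropyl on an aromatic nitrogen made a 1.1-fold higher number from compound 1 to compound 2 (0.04 log units; within the scatter). chloro in place of fluoro on an aromatic carbon made a 1.2-fold lower number from compound 1 to compound 3 (0.08 log units; within the scatter). All three values sit within the usual scatter of one another, so no order among them is claimed and none is called stronger or weaker.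

Compound 4 `Cn1c(/C=C2/C(=O)Nc3ccc(Cl)cc32)nc2ccccc21` has not been measured. It differs from compound 3 by methyl in place of isopropyl on an aromatic nitrogen. This is the same change as that between compound 1 and compound 2; the place lines of the two agree word for word. The two cores on which the change is made differ by chloro in place of fluoro on an aromatic carbon.

For compound 4 the expected step is a 1.1-fold higher number from compound 3 to compound 4 (0.03 log units; within the scatter), set beside the measured 1.1-fold higher number from compound 1 to compound 2 (0.04 log units; within the scatter). This expectation rests on a single measured pair; on the core bearing chloro there is no second example of the change, and the carryover from one core to the other is assumed, not shown. In this assay compound 4 is therefore estimated at 26000 nM. The estimate for compound 4 is expected to fall between 13000 nM and 52000 nM.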

Compound 4, half-maximal inhibitory concentration: > 50000 nM
Compound 4 ended at the assay's limit; the forecaster's own chance of this, stated with the estimate: 10%; middle value at least 1.9-fold (0.28 log units) away from the limit.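

In this assay compound 4 stands at > 50000 nM, which is a limit of the assay and not a number. On these data alone, on the core bearing chloro, methyl in place of isopropyl on the aromatic nitrogen made an at least 2.0-fold higher number from compound 3 to compound 4 (0.31 log units; beyond the scatter), so a step beyond the scatter is seen on this core, but the true size of the step stays unknown and the notes cannot say that the change behaves differently on the two cores: the same change on two cores in this assay, a 1.1-fold higher number (0.04 log units; within the scatter) from compound 1 to compound 2 and an at least 2.0-fold higher number (0.31 log units; beyond the scatter) from compound 3 to compound 4; the limit leaves it open whether they differ. Read the other way, chloro in place of fluoro on an aromatic carbon, now on the methyl compounds, made an at least 1.5-fold higher number from compound 2 to compound 4 (0.19 log units; that floor lies within the scatter), and this step too gives no proof that the halogen swap fails to carry over between the isopropyl and methyl cores: the same change on two cores in this assay, a 1.2-fold lower number (0.08 log units; within the scatter) from compound 1 to compound 3 and an at least 1.5-fold higher number (0.19 log units; that floor lies within the scatter) from compound 2 to compound 4; the limit leaves it open whether they differ.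

For the compounds shown here, each core carries only one example of each change, so the series offers no basis for a general rule about carrying either change over. Still open, as far as these compounds go, is what other groups on the aromatic nitrogen would give, such as an ethyl, a longer chain or a chain ending in an amine, and what a bromo or a nitrile would give in place of the halogen.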